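Naphthalen-1-yl in place of phenyl: outlook for compound 3

The source may hold more compounds than are shown below. What is called first, only, known or untested is meant among the compounds shown, and "the series" means these compounds.

Measured so far:
compound 1 `O=C1OC2(CCN(Cc3ccccc3)CC2)c2csc(-c3ccccc3)c21`: 11 nM
compound 2 `O=C1OC2(CCN(Cc3ccccc3)CC2)c2c(-c3ccccc3)sc(-c3ccccc3)c21`: 87 nM

In an assay on membranes from brain for displacement of a labelled ligand from Sigma non-opioid intracellular receptor 1 (Cavia porcellus), read by scintillation counting, with a stated time of 120 min (on this read-out lower numbers stand for stronger inhibition and higher numbers for weaker inhibition), compound 1 gives 11 nM, the lowest of the two numbers in hand. For the measured compounds named here, compound 2 gives 87 nM; the only measured step, a 7.9-fold higher number from compound 1 to compound 2 (0.90 log units; beyond the scatter), is phenyl in place of hydrogen on an aromatic carbon. Compound 3 `O=C1OC2(CCN(Cc3ccccc3)CC2)c2csc(-c3cccc4ccccc34)c21` differs from compound 1 by naphthalen-1-yl in place of phenyl on an aromatic carbon. Going by the values given here, no measured step enlarges the aryl group already present on this carbon; the measured step adds a further phenyl rather than growing the existing one, so it bears on compound 3 only loosely, and its modest size suggests that extra aromatic bulk on the core is tolerated rather than strongly punished. A small loss in this assay, within or just beyond the scatter, is therefore the working expectation. Compound 3 is expected near 20 nM, with a range from 6 nM to 70 nM. This estimate corresponds to an expected step of a 1.8-fold higher number from compound 1 to compound 3 (0.26 log units; within the scatter).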

Compound 3, inhibition constant: 5.3 nM
Beside the measured number, compound 3's estimate is 3.8-fold (0.58 log units) above it; measured number outside the range, below it.
By their numbers in this assay, from the lowest: compound 3; then compound 1; then compound 2.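

Enlarging the aryl group on the aromatic carbon next to the ring sulfur is accepted in this assay, and naphthalen-1-yl in place of phenyl gives a 2.1-fold lower number from compound 1 to compound 3 (0.32 log units; beyond the scatter) as a modest step beyond the scatter. For the compounds shown here, this is the first measured change to the aryl group already on this carbon, and its direction is opposite to that of phenyl in place of hydrogen, which gives a 7.9-fold higher number from compound 1 to compound 2 (0.90 log units; beyond the scatter) in the same assay. Added aromatic rings therefore do not shift the number in one direction across the compounds shown, and nothing in hand accounts for the difference.

On these data alone, it remains open whether the lower number is specific to naphthalen-1-yl or is shared by naphthalen-2-yl or a biphenyl group on the same carbon. Also open, as far as these compounds go, is how a pyridine ring, a methoxy group or an amine at this position would read.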